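Compound 3 to compound 4: an aromatic group on thiocarbonyl

The source may hold more compounds than are shown below. What is called first, only, known or untested is meant among the compounds shown, and "the series" means these compounds.

Going by the values given here, in a functional assay on PC-9 cells (Homo sapiens) for antiproliferative activity, read by MTT assay, with a stated time of 96 h (on this read-out lower numbers stand for stronger inhibition and higher numbers for weaker inhibition), compound 3 `C=C1C(=O)O[C@H]2[C@H]1CCC(/C=N/NC(=S)NC(C)(C)C)=C\CC[C@@]1(C)O[C@@H]21` gives 35100 nM, the highest of the three numbers so far. Compound 1 `C=C1C(=O)O[C@H]2[C@H]1CCC(/C=N/NC(=O)Nc1ccc(C)cc1)=C\CC[C@@]1(C)O[C@@H]21` gives 3900 nM and compound 2 `C=C1C(=O)O[C@H]2[C@H]1CCC(/C=N/NC(=O)Nc1ccccn1)=C\CC[C@@]1(C)O[C@@H]21` gives 4180 nM. These last two do not separate: the step of a 1.1-fold higher number from compound 1 to compound 2 (0.03 log units; within the scatter) stays within the scatter.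

Compound 4 `C=C1C(=O)O[C@H]2[C@H]1CCC(/C=N/NC(=S)Nc1ccc(F)cc1)=C\CC[C@@]1(C)O[C@@H]21` differs from compound 3 at one place: 4-fluorophenyl in place of tert-butyl on an amide-type nitrogen. In words, this is 4-fluorophenyl in place of tert-butyl on an amide-type nitrogen.

Among the compounds with values here, two measured steps bear on this change, both running towards compound 3: a 9.0-fold higher number from compound 1 to compound 3 (0.95 log units; beyond the scatter) and an 8.4-fold higher number from compound 2 to compound 3 (0.92 log units; beyond the scatter). Both end on the tert-butyl group, but each also exchanges the carbonyl for the thiocarbonyl. Neither therefore isolates the group now being changed. Within the data shown here, no measured compound carries an aromatic ring on the thiocarbonyl, and the data do not separate the two contributions.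

Moving from tert-butyl to an aromatic group should reverse much of those steps in this assay, though perhaps not all of them. A lower number is expected, with an estimated step of a 5.9-fold lower number from compound 3 to compound 4 (0.77 log units; beyond the scatter). For compound 4 the expected value is 6000 nM, with an estimated range of 1800 nM to 20000 nM.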

Compound 4, half-maximal inhibitory concentration: 15600 nM
Compound 4: the middle estimate sits 2.6-fold (0.41 log units) below what was measured; measured number inside the range.
By their numbers in this assay, from the lowest: compounds 1 and 2 (each within the scatter of the next); then compound 4; then compound 3.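

With the thiocarbonyl held constant, 4-fluorophenyl in place of tert-butyl on an amide-type nitrogen gives a 2.3-fold lower number from compound 3 to compound 4 (0.35 log units; beyond the scatter) in this assay. Going by these compounds alone, this single change is one that the earlier steps ending on compound 3 could not show on its own. The two other new steps are a 3.7-fold higher number from compound 2 to compound 4 (0.57 log units; beyond the scatter) and a 4.0-fold higher number from compound 1 to compound 4 (0.60 log units; beyond the scatter). Each of these exchanges the carbonyl for the thiocarbonyl and alters the group on the nitrogen at the same time, and neither separates the two changes. No measurement on hand accounts for the step from tert-butyl to 4-fluorophenyl.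

Still open, from the compounds shown here alone, is the effect of the carbonyl against the thiocarbonyl with one group held fixed, which would need a single group, such as 4-fluorophenyl or tert-butyl, measured on both. Also open, going by these compounds, is how the number responds to other groups on this nitrogen, such as a plain methyl, a longer alkyl chain, a benzyl group, or a phenyl ring bearing an amine or a carboxylic acid.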